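A few compounds are considered here, and "the series" means these few. Any claim that something is new, unique, unknown or untested is made for them only; others in the source may bear on it.

Compound 1 `O=c1cc(CSC(=S)N2CCCCC2)oc2cc(Cl)ccc12` and compound 3 `CCOC(=O)c1cc(=O)c2cc(CSC(=S)N3CCCCC3)ccc2o1` both carry piperidin-1-yl on the thiocarbonyl carbon and differ in their cores; the difference between the two cores is not broken down here. In a functional assay on MDA-MB-435S cells (Homo sapiens) for antiproliferative activity, read by MTT assay, with a stated time of 72 h (a higher number here means a weaker inhibitor, a lower number a stronger inhibitor), compound 1 gives 3000 nM. In this assay compound 3 gives 2900 nM, which lies within the scatter of the value for compound 1.

Compound 2 `O=c1cc(CSC(=S)N2CCOCC2)oc2cc(Cl)ccc12` differs from compound 1 in one place: morpholin-4-yl in place of piperidin-1-yl on a thiocarbonyl carbon. In this assay compound 2 reaches only a limit of the assay, > 25000 nM, and the limit of > 25000 nM in this assay, at which 1 of the 3 values shown sits, records that one value sits there. The step is an at least 8.3-fold higher number from compound 1 to compound 2 (0.92 log units; beyond the scatter).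

Compound 4 `CCOC(=O)c1cc(=O)c2cc(CSC(=S)N3CCOCC3)ccc2o1` is not yet measured in this assay. It stands to compound 3 as compound 2 stands to compound 1: morpholin-4-yl in place of piperidin-1-yl on a thiocarbonyl carbon. The place is the same word for word in both pairs, so this is the same change, not merely the same kind of change, and it occurs twice among the compounds shown.

Because compound 3 gives 2900 nM and the same change already produced an at least 8.3-fold higher number from compound 1 to compound 2 (0.92 log units; beyond the scatter), the step from compound 3 to compound 4 is expected to be about an 8.6-fold higher number from compound 3 to compound 4 (0.94 log units; beyond the scatter). Compound 4 is therefore estimated at 25000 nM in this assay, with a range from 8000 nM to 70000 nM, and it is likely that only a limit will be reported.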

Compound 4, half-maximal inhibitory concentration: > 25000 nM
Compound 4 ended at the assay's limit; the forecaster's own chance of this, stated with the estimate: 55%; the middle value sits exactly at the limit.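

In this assay, the change to morpholin-4-yl in place of piperidin-1-yl on a thiocarbonyl carbon again weakens the series on the second core, with an at least 8.6-fold higher number from compound 3 to compound 4 (0.93 log units; beyond the scatter). Compound 4 gives > 25000 nM, which is a limit of the assay and not a number. The notes therefore support a shared direction for this change on the two cores shown, but not a shared size and not a rule for other cores: the same change on two cores in this assay, an at least 8.3-fold higher number (0.92 log units; beyond the scatter) from compound 1 to compound 2 and an at least 8.6-fold higher number (0.93 log units; beyond the scatter) from compound 3 to compound 4; the limit leaves it open whether they differ

Still open, as far as these compounds go, is how other groups on the thiocarbonyl carbon would read on these two cores, for example pyrrolidin-1-yl, 4-methylpiperazin-1-yl or an open-chain diethylamino group, and whether any of them would keep a measurable value where morpholin-4-yl does not. Also open, from the compounds shown here alone, is how far the reading of compound 3 depends on its ethyl ester, which a carboxylic acid or a primary amide in its place would test while piperidin-1-yl stays unchanged.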